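A few compounds are considered here, and "the series" means these few. Any claim that something is new, unique, unknown or untested is made for them only; others in the source may bear on it.

Of the compounds shown here, three from one series have been measured in a functional assay on HeLa cells (Homo sapiens) for cytotoxicity, read by MTT assay, with a stated time of 72 h; on this read-out higher numbers stand for weaker inhibition and lower numbers for stronger inhibition. Compound 1 `Cc1cccc(CSc2cc(Cl)c(C)cc2S(=O)(=O)/N=C(\N)n2nccc2-c2ccccc2)c1` gives 8000 nM, and compound 2 `Cc1cc(-c2ccccc2)n(/C(N)=N/S(=O)(=O)c2cc(C)c(Cl)cc2SCc2cccc3ccccc23)n1` gives 3000 nM. Compound 3 `Cc1cc(S(=O)(=O)/N=C(\N)n2nccc2-c2ccccc2)c(SCc2ccc(C(F)(F)F)cc2)cc1Cl` gives 17000 nM, the highest number of the three: compound 1 lies nearest to it, compound 2 furthest from it.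

For the measured compounds named here, only one measured step bears directly on compound 3. It runs a 2.1-fold higher number from compound 1 to compound 3 (0.33 log units; beyond the scatter), a modest worsening.

Compound 4 `Cc1cc(S(=O)(=O)/N=C(\N)n2nccc2-c2ccccc2)c(SCc2cccc3ccccc23)cc1Cl` is not yet measured. It differs from compound 3 in one place: naphthalen-1-yl in place of 4-(trifluoromethyl)phenyl on a saturated chain carbon bound to a sulfur. Going by the values given here, compound 2 carries the same ((naphthalen-1-yl)methyl)sulfanyl group but differs from compound 4 elsewhere in its core, so no clean step connects it to compound 3; its value, set beside that of compound 3, simply shows a much lower number for the naphthyl-bearing compound 2.

Since swapping a 3-methylphenyl for the 4-(trifluoromethyl)phenyl moved compound 1 to compound 3 only modestly, and since compound 2 with the naphthyl group sits well below compound 3, compound 4 is expected to come in lower than compound 3, by roughly a 3.4-fold lower number from compound 3 to compound 4 (0.53 log units; beyond the scatter). The estimate for compound 4 in this assay is therefore 5000 nM, with a plausible range from 2000 nM to 14000 nM.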

Compound 4, half-maximal inhibitory concentration: 3000 nM
The estimate for compound 4 lay 1.7-fold (0.22 log units) above the measured number; low and high end bracket the measured number.
By their numbers in this assay, from the lowest: compounds 2 and 4 (each within the scatter of the next); then compound 1; then compound 3.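

On a saturated chain carbon bound to a sulfur, naphthalen-1-yl in place of 4-(trifluoromethyl)phenyl gives a 5.7-fold lower number from compound 3 to compound 4 (0.75 log units; beyond the scatter) in this assay, and naphthalen-1-yl in place of 3-methylphenyl gives a 2.7-fold lower number from compound 1 to compound 4 (0.43 log units; beyond the scatter), so with the rest of the molecule held the same, this group gives a lower number than either substituted phenyl group shown. Compound 2 had hinted at this but differed from the others in more than one place, whereas hydrogen in place of methyl on an aromatic carbon now gives no change at the digits printed from compound 2 to compound 4 (within the scatter), which ties the low number of compound 2 to its naphthalen-1-yl group and shows that this methyl makes no readable difference here. Nothing measured here explains why the naphthalen-1-yl compounds give lower numbers.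

The compounds shown leave open whether a longer chain carrying the naphthalen-1-yl group on the sulfur, or an amine on that group, would keep the number this low. They also leave open whether the same order would hold on other cell types, since all four values come from this assay.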